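Aryl change on the cyanoguanidine series: compound 2 to compound 3

The compounds below may be only part of what the source reports. "The series", "measured", "known", "first", "only" and "open" are said of these compounds alone.

Measured in a functional assay (aorta) with Rattus norvegicus as the target; on this read-out lower numbers stand for stronger inhibition and higher numbers for weaker inhibition:
- Compound 1 `CC1(C)Oc2ccc(C#N)cc2[C@@H](/N=C(\NC#N)Nc2ccc(C(=O)O)cc2)[C@@H]1O`: > 100000 nM (a limit)
- Compound 2 `Cc1cccc(N/C(=N/[C@@H]2c3cc(C#N)ccc3OC(C)(C)[C@H]2O)NC#N)c1`: 1000 nM

For the measured compounds named here, compound 2 holds the only actual number so far in this assay, at 1000 nM. Compound 1 stands at a limit of the assay, not at a number.

Compound 3 `CC1(C)Oc2ccc(C#N)cc2[C@@H](/N=C(\NC#N)Nc2ccc(Cl)c(F)c2)[C@@H]1O` keeps the core of compound 2 and changes one group: 4-chloro-3-fluorophenyl in place of 3-methylphenyl on an amine nitrogen. This puts 4-chloro-3-fluorophenyl in place of 3-methylphenyl on an amine nitrogen.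

Going by the values given here, one measured step bears on this, made at the same nitrogen: an at least 100-fold lower number from compound 1 to compound 2 (2.00 log units; beyond the scatter). It was large and shows that the group at this place can move the read-out strongly. A single step gives no trend for halogen-bearing phenyl groups. With compound 2 at 1000 nM as the starting point and one substituted phenyl replacing another, a far smaller step is expected, modestly towards a lower number and perhaps not beyond the scatter.

The expected step is a 2.0-fold lower number from compound 2 to compound 3 (0.30 log units; within the scatter). For compound 3 the estimated value is 500 nM, with an expected range of 120 nM to 2500 nM.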

Compound 3, half-maximal inhibitory concentration: 1660 nM
Compound 3: the middle estimate sits 3.3-fold (0.52 log units) below what was measured, and the stated range covers the measured number.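

In this assay, 4-chloro-3-fluorophenyl in place of 3-methylphenyl on the amine nitrogen gives a 1.7-fold higher number from compound 2 to compound 3 (0.22 log units; within the scatter), so these two substituted phenyl groups cannot be told apart on this read-out. With 4-chloro-3-fluorophenyl in place of 4-carboxyphenyl, the result is an at least 60-fold lower number from compound 1 to compound 3 (1.77 log units; beyond the scatter), which, read with an at least 100-fold lower number from compound 1 to compound 2 (2.00 log units; beyond the scatter), shows that the large separation at this nitrogen belongs to 4-carboxyphenyl alone among the three groups shown, not to the one pair of groups first compared. Compound 1 stands at a limit and not at a number, so the true size of both steps from it stays unknown: the limit of > 100000 nM in this assay, at which 1 of the 3 values shown sits.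

Still open, from the compounds shown here alone, is whether the separation seen with 4-carboxyphenyl belongs to the carboxylic acid itself or would also appear with a methyl ester or a primary amide in its place. Also open, going by these compounds, is how far a cyclohexyl group or a longer alkyl chain on the same nitrogen, in place of the phenyl ring, would move the read-out from the level shared by compound 2 and compound 3.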